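The source may report more compounds than this note shows. Statements on the series, on what has been measured and on what is new or still open speak of the compounds shown alone.

Working notes on the series in a functional assay on HCT-116 cells (Homo sapiens) for cytotoxicity, read by MTT assay, with a stated time of 48 h; on this read-out lower numbers stand for stronger inhibition and higher numbers for weaker inhibition.

Compound 1 `CCN(CC)c1ccc2cc(C(=O)c3ccc(N4CCN(C(=O)CN5CCN(C(=O)CCl)CC5)CC4)cc3)oc2c1` carries a (chloromethyl)carbonyl on the ring amine nitrogen of the shared core. In this assay compound 1 reaches only the assay limit > 40000 nM and gives no number. Compound 2 `CCN(CC)c1ccc2cc(C(=O)c3ccc(N4CCN(C(=O)CN5CCN(Cc6ccc(F)c(F)c6)CC5)CC4)cc3)oc2c1`, with a 3,4-difluorobenzyl in that place, gives 26300 nM in this assay. Compound 3 `CCN(CC)c1ccc2cc(C(=O)c3ccc(N4CCN(C(=O)CN5CCN(Cc6ccc(C(F)(F)F)cc6)CC5)CC4)cc3)oc2c1`, with a 4-(trifluoromethyl)benzyl, again returns only the limit > 40000 nM in this assay. The step of an at least 1.5-fold lower number from compound 1 to compound 2 (0.18 log units; that floor lies within the scatter) is the one readable movement; the step that the two limits leave unreadable from compound 1 to compound 3 cannot be sized, and the step of an at least 1.5-fold higher number from compound 2 to compound 3 (0.18 log units; that floor lies within the scatter) is bounded only at its floor. Two of the three values sit at the limit of > 40000 nM in this assay, at which 2 of the 3 values shown sit, so the whole series is weakly active at best.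

Compound 4 `CCN(CC)c1ccc2cc(C(=O)c3ccc(N4CCN(C(=O)CN5CCN(Cc6ccc(C#N)cc6)CC5)CC4)cc3)oc2c1` is not yet measured. It differs from compound 1 by 4-cyanobenzyl in place of (chloromethyl)carbonyl on an amine nitrogen in a ring. Among the compounds with values here, the steps that bear on this change are the two other benzyl replacements from compound 1, an at least 1.5-fold lower number from compound 1 to compound 2 (0.18 log units; that floor lies within the scatter) and a step that the two limits leave unreadable from compound 1 to compound 3, both small or unreadable. For compound 4 the expected step is therefore an at least 1.1-fold lower number from compound 1 to compound 4 (0.05 log units; that floor lies within the scatter), no movement beyond the scatter. The estimate for compound 4 in this assay is 35000 nM, with a range from 15000 nM to 80000 nM, and a real chance of only a limit being reported.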

Compound 4, half-maximal inhibitory concentration: > 40000 nM
Compound 4 ended at the assay's limit; the forecaster's own chance of this, stated with the estimate: 50%; middle value at least 1.1-fold (0.05 log units) from the limit.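

In this assay compound 4 returns only the assay limit > 40000 nM. At this amine nitrogen in a ring, 4-cyanobenzyl in place of (chloromethyl)carbonyl therefore yields no number, and the same holds for the change to cyano in place of trifluoromethyl on an aromatic carbon, so 4-cyanobenzyl and 4-(trifluoromethyl)benzyl both end without a measured value. The steps from compound 1 and from compound 3 to compound 4 cannot be read, the only readable one is an at least 1.5-fold higher number from compound 2 to compound 4 (0.18 log units; that floor lies within the scatter), and compound 2 is now the single compound in the series with a number: the limit of > 40000 nM in this assay, at which 3 of the 4 values shown sit.

Open at this ring nitrogen are a plain benzyl, a 4-methoxybenzyl or a longer alkyl chain in place of the groups shown. As far as these compounds go, the true size of each step that ends at the limit also stays unknown, and with only compound 2 carrying a number, no ranking of the benzyl groups can be drawn.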